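Nitro for iodo on the aryl tail: compound 4

This account rests on a few compounds, and the source may have more. Where it says the series, first, only, none or still open, it means among the compounds named here.

compound 1 `O=C(O)CCCO/N=c1/ccn([C@@H]2O[C@H](COP(=O)(O)OP(=O)(O)OP(=O)(O)O)[C@@H](O)[C@H]2O)c(=O)[nH]1` — 470 nM
compound 2 `O=c1[nH]/c(=N\OCCCc2cccc(F)c2)ccn1[C@@H]1O[C@H](COP(=O)(O)OP(=O)(O)OP(=O)(O)O)[C@@H](O)[C@H]1O` — 100 nM
compound 3 `O=c1[nH]/c(=N\OCCCc2ccc(I)cc2)ccn1[C@@H]1O[C@H](COP(=O)(O)OP(=O)(O)OP(=O)(O)O)[C@@H](O)[C@H]1O` — 91 nM

In a functional assay on 1321-N1 cells for agonist activity at P2Y purinoceptor 4 (Homo sapiens), read by scintillation counting and inositol phosphate accumulation (on this read-out lower numbers stand for an effect already at smaller amounts and higher numbers for an effect only at larger amounts of compound), compound 3 gives the lowest number of the three, yet a 1.1-fold lower number from compound 2 to compound 3 (0.04 log units; within the scatter) is within the scatter, so compound 2 and compound 3 cannot be ordered. Both sit well apart from compound 1: a 4.7-fold lower number from compound 1 to compound 2 (0.67 log units; beyond the scatter) and a 5.2-fold lower number from compound 1 to compound 3 (0.71 log units; beyond the scatter).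

Compound 4 `O=c1[nH]/c(=N\OCCCc2ccc([N+](=O)[O-])cc2)ccn1[C@@H]1O[C@H](COP(=O)(O)OP(=O)(O)OP(=O)(O)O)[C@@H](O)[C@H]1O` carries nitro in place of iodo on an aromatic carbon. For the measured compounds named here, the only step that bears on a swap of one aromatic substituent for another is a 1.1-fold lower number from compound 2 to compound 3 (0.04 log units; within the scatter), and it was within the scatter. The steps from compound 1 concern the carboxy to aryl exchange and say nothing about substituents on the ring. In this assay compound 4 is therefore expected to show no step beyond the scatter, a 1.1-fold higher number from compound 3 to compound 4 (0.04 log units; within the scatter), with an estimate of 100 nM (range 40 nM to 250 nM).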

Compound 4, half-maximal effective concentration: 84 nM
Compound 4: middle estimate off by 1.2-fold (0.08 log units), on the high side; measured number inside the range.
By their numbers in this assay, from the lowest: compounds 4, 3 and 2 (each within the scatter of the next); then compound 1.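

In this assay, nitro in place of iodo on an aromatic carbon, para to a large group, gives no readable difference (a 1.1-fold lower number from compound 3 to compound 4 (0.03 log units; within the scatter)). The 4-nitrophenyl tail also cannot be separated from the 3-fluorophenyl tail (a 1.2-fold lower number from compound 2 to compound 4 (0.08 log units; within the scatter)), yet it stands clear of the carboxy end (a 5.6-fold lower number from compound 1 to compound 4 (0.75 log units; beyond the scatter)), so the gain seen for the aryl tails holds with nitro, a group with hydrogen-bond acceptors, as with iodo, which has none; no measurement at hand offers a reason for this. Open remain an amine or a carboxylic acid on the ring, and a shorter or longer chain carrying the 4-nitrophenyl.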